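Isopropyl to tert-butyl: cytotoxicity limit expected to hold

The source may hold more compounds than are shown below. What is called first, only, known or untested is meant among the compounds shown, and "the series" means these compounds.

Compound 2 `Cc1ccc2cc(CN(Cc3ccc(F)cc3)Cc3ccc(C(C)C)cc3)c(=O)[nH]c2c1` is the reference point of the series. In a toxicity assay on MDCK cells (Canis lupus familiaris) for cytotoxicity, read by crystal violet staining, with a stated time of 48 h (a higher number here means that more compound is tolerated, a lower number that less compound is tolerated), compound 2 gives > 33000 nM, which is a limit of the assay and not a number. Its two measured neighbours are compound 1 `Cc1ccc2cc(C(C)N(Cc3ccc(F)cc3)Cc3ccc(C(C)C)cc3)c(=O)[nH]c2c1` and compound 3 `Cc1ccc2cc(CN(Cc3ccc(C(C)C)cc3)Cc3cccc(F)c3)c(=O)[nH]c2c1`. In this assay compound 1 gives > 33000 nM, likewise a limit. In this assay compound 3 gives > 33000 nM, also a limit. Within the data shown here, the two measured steps, a step that the two limits leave unreadable from compound 1 to compound 2 and a step that the two limits leave unreadable from compound 2 to compound 3, are therefore unreadable in size, as the limit of > 33000 nM in this assay, at which 3 of the 3 values shown sit, shows: every value so far sits at that limit.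

Compound 4 `Cc1ccc2cc(CN(Cc3ccc(F)cc3)Cc3ccc(C(C)(C)C)cc3)c(=O)[nH]c2c1` differs from compound 2 by methyl in place of hydrogen on a saturated chain carbon bound to an aromatic carbon and two saturated chain carbons. Neither measured step bears on this change in a readable way, and both show only that the limit is reached. From compound 2 to compound 4 the expected step in this assay is none beyond the scatter, that is a step that the limit leaves unreadable from compound 2 to compound 4, with the result most likely again reported as a limit. Compound 4 is expected to give 50000 nM in this assay, within a range from 20000 nM to 150000 nM.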

Compound 4, half-maximal cytotoxic concentration: > 33000 nM
Compound 4 was reported as a limit; the forecaster's own chance of this, stated with the estimate: 85%; the middle value lies beyond the limit too.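

Compound 2 and compound 4 are both reported only as limits, so no step between them can be read: the limit of > 33000 nM in this assay, at which 4 of the 4 values shown sit.

The compounds shown leave open how far any of them lies from that limit, and whether any change among them shifts the tolerated concentration at all.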